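Cyclobutyl in place of fluoropyridine: will stability fall?

The source may report more compounds than this note shows. Statements on the series, on what has been measured and on what is new or still open speak of the compounds shown alone.

Compound 2 `CS(=O)(=O)Nc1ccc2c(c1)S(=O)(=O)N=C(C1=C(O)C3CCCC3N(Cc3ccc(F)cn3)C1=O)N2` stands at the top of the values seen here. In an in vitro ADME assay on microsomes from liver (Homo sapiens) for metabolic stability (a higher number here means that the compound lasts longer, a lower number that the compound disappears faster), compound 2 gives > 1 h, which is a limit of the assay rather than a number (the limit of > 1 h in this assay, at which 1 of the 3 values shown sits). Compound 1 `CS(=O)(=O)Nc1ccc2c(c1)S(=O)(=O)N=C(C1=C(O)C3CCCC3N(CCC3CC3)C1=O)N2` gives 0.417 h in this assay, and compound 3 `CC(C)CCN1C(=O)C(C2=NS(=O)(=O)c3cc(NS(C)(=O)=O)ccc3N2)=C(O)[C@H]2CCC[C@H]21` gives 0.383 h. Within the data shown here, the single measured step, an at least 2.3-fold higher number from compound 1 to compound 2 (0.37 log units; beyond the scatter), is the only comparison that bears on the change at hand. Compound 4 `CS(=O)(=O)Nc1ccc2c(c1)S(=O)(=O)N=C(C1=C(O)C3CCCC3N(CC3CCC3)C1=O)N2` carries cyclobutyl in place of 5-fluoropyridin-2-yl on a saturated chain carbon bound to an amide-type nitrogen in a ring, which largely undoes that step by returning a small saturated ring to the chain carbon. A drop of roughly the same size is therefore expected, giving an at least 2.2-fold lower number from compound 2 to compound 4 (0.34 log units; beyond the scatter). Compound 4 is estimated at 0.45 h, with a likely range from 0.25 h to 0.9 h.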

Compound 4, half-life: 0.0667 h
Estimate against measurement, compound 4: 6.7-fold (0.83 log units) above, outside the stated range (below it).
By their numbers in this assay, from the lowest: compound 4; then compounds 3 and 1 (each within the scatter of the next). At a limit, above all of these: compound 2.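

In this assay, the position proves sensitive even among saturated groups alone: cyclobutyl in place of cyclopropylmethyl gives a 6.3-fold lower number from compound 1 to compound 4 (0.80 log units; beyond the scatter). Cyclobutyl in place of 5-fluoropyridin-2-yl gives an at least 14-fold lower number from compound 2 to compound 4 (1.17 log units; beyond the scatter). The true size of that step stays open, since compound 2 gives a limit rather than a number: the limit of > 1 h in this assay, at which 1 of the 4 values shown sits.

Going by these compounds, whether the longer survival of compound 2 belongs to the aromatic ring or to its fluorine remains open. So does how a plain phenyl ring, an unsubstituted pyridine or an amine would behave on the same chain carbon.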